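Replacing 3-chlorophenyl in compound 2 to reach compound 4

The source may report more compounds than this note shows. Statements on the series, on what has been measured and on what is new or still open speak of the compounds shown alone.

Among the measured compounds shown here, in a functional assay on A549 cells (Homo sapiens) for antiproliferative activity, read by MTT assay, with a stated time of 24 h (a lower number here means a stronger inhibitor, a higher number a weaker inhibitor), compound 2 (`O=C(NNc1cccc(Cl)c1)c1ccccc1NS(=O)(=O)c1cnc(O)nc1O`) gives 5290 nM as the only number. Compound 1 (`O=C(NNc1ccc(F)cc1)c1cccc(NS(=O)(=O)c2cnc(O)nc2O)c1`) gives > 20000 nM which is a limit. Compound 3 (`Cc1ccc(C(=O)NNC(=O)c2cccc(NS(=O)(=O)c3cnc(O)nc3O)c2)cc1`) gives > 20000 nM which is also a limit.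

Compound 4 (`Cc1ccccc1C(=O)NNC(=O)c1ccccc1NS(=O)(=O)c1cnc(O)nc1O`) differs from compound 2 by (2-methylphenyl)carbonyl in place of 3-chlorophenyl on an amine nitrogen with (2-methylphenyl)carbonyl in place of 3-chlorophenyl on an amine nitrogen. The closest measured change is a step that the two limits leave unreadable from compound 1 to compound 3 and it offers no size to carry over. The only hint of direction is the limit of > 20000 nM in this assay, at which 2 of the 3 values shown sit, and it leans slightly toward weaker inhibition. An estimated 1.5-fold higher number from compound 2 to compound 4 (0.18 log units; within the scatter) is expected in this assay and this lies within the scatter, so no real step is expected. The expected value for compound 4 is 8000 nM in this assay with an estimated range from 2500 nM to 20000 nM for this wide and poorly anchored case.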

Compound 4, half-maximal inhibitory concentration: 5450 nM
Compound 4: the middle estimate sits 1.5-fold (0.17 log units) above what was measured; the range from low to high includes it.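

In this assay, (2-methylphenyl)carbonyl in place of 3-chlorophenyl on an amine nitrogen gives a 1.0-fold higher number from compound 2 to compound 4 (0.01 log units; within the scatter). Among the compounds shown here, this is the first readable step for an exchange on this nitrogen, since the only earlier one, between compound 1 and compound 3, joins two limits and cannot be read. For the compounds shown here, with the core of compound 2 held, the group here can therefore take on a carbonyl and a methyl-bearing aromatic ring in place of a chlorine-bearing one with no real step in this read-out.

Much of the series remains without a number in this assay: the limit of > 20000 nM in this assay, at which 2 of the 4 values shown sit. Still open, as far as these compounds go, is whether an aliphatic amine or a carboxylic acid on this nitrogen, in place of the aromatic groups, would move the value beyond the scatter.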